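A few compounds are considered here, and "the series" means these few. Any claim that something is new, unique, unknown or untested is made for them only; others in the source may bear on it.

Measured in an ADME assay on Vero cells (Chlorocebus sabaeus) for cytotoxicity, read by MTT assay, with a stated time of 96 h; a lower number here means that less compound is tolerated, a higher number that more compound is tolerated:
Compound 1 `CC(=O)c1ccc2[nH]c(-c3ccccc3)nc2c1`: > 100000 nM, a limit
Compound 2 `C/C(=N\O)c1ccc2[nH]c(-c3ccccc3)nc2c1`: > 100000 nM, a limit

Compound 2 gives no number, only the limit > 100000 nM. It stands at the limit of > 100000 nM in this assay, at which 2 of the 2 values shown sit. Compound 3 `C/C(=N\NC(N)=O)c1ccc2[nH]c(-c3ccccc3)nc2c1` carries ureido in place of hydroxy on a double-bonded nitrogen. Among the measured compounds shown here, the only measured step bearing on this is a step that the two limits leave unreadable from compound 1 to compound 2, so it offers no size to carry over. In this assay, no change beyond the scatter is therefore expected, and compound 3 should most likely reach the same limit. The estimated step is a number no higher from compound 2 to compound 3 (the limit leaves the size open). For compound 3 the estimated value is 100000 nM, with an expected range from 30000 nM to 200000 nM.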

Compound 3, half-maximal cytotoxic concentration: > 100000 nM
Compound 3 ended at the assay's limit; the forecaster's own chance of this, stated with the estimate: 75%; the middle value sits exactly at the limit.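

In this assay, among the compounds shown here, compound 3 gives > 100000 nM, a limit, so no step linking it to compound 1 or compound 2 can be read. The compounds shown leave open where each half-maximal cytotoxic concentration actually lies and whether these groups differ at all: the limit of > 100000 nM in this assay, at which 3 of the 3 values shown sit.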